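From 4-ethylpiperazin-1-yl to 3,4-dimethylpiperazin-1-yl in compound 3

A few compounds are considered here, and "the series" means these few. Any claim that something is new, unique, unknown or untested is made for them only; others in the source may bear on it.

Compound 1 `COc1nc(CN(C)C2CCCc3cccnc32)cc(N2CCN(C)CC2)n1` gives 0.0367 h
Compound 2 `CCN1CCN(c2cc(CN(C)[C@H]3CCCc4cccnc43)nc(C)n2)CC1` gives 0.019 h

Both compounds were tested in an ADME assay on microsomes from liver (Rattus norvegicus) for metabolic stability, read by LC-MS, using NADPH, with stated times of 10 min and 60 min (on this read-out lower numbers stand for a shorter-lived compound and higher numbers for a longer-lived compound), and so far are the only measured points. Compound 2 stands level with compound 1 on this read-out, since the two numbers lie within the usual scatter of each other. Among the measured compounds shown here, the two structures differ in more than one place, so no measured step shows what a single change does here.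

Compound 3 `Cc1nc(CN(C)[C@H]2CCCc3cccnc32)cc(N2CCN(C)[C@@H](C)C2)n1` keeps the rest of compound 2 and carries 3,4-dimethylpiperazin-1-yl in place of 4-ethylpiperazin-1-yl on an aromatic carbon. The two have the same atoms, joined differently, and the new group has one defined stereocentre. For the measured compounds named here, no measured pair isolates this kind of change, so the expectation rests only on compound 2 (0.019 h) as the closest measured neighbour. The expected step of a 1.1-fold higher number from compound 2 to compound 3 (0.04 log units; within the scatter) stays within the scatter, with no direction expected. In this assay the estimate for compound 3 is 0.021 h (expected range 0.01 h to 0.045 h).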

Compound 3, half-life: 0.0267 h
Beside the measured number, compound 3's estimate is 1.3-fold (0.10 log units) below it; the range from low to high includes it.
By their numbers in this assay, from the lowest: compounds 2, 3 and 1 (each within the scatter of the next).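

With compound 3 the series gains its first step that changes only one place, and in this assay that step reads a 1.4-fold higher number from compound 2 to compound 3 (0.15 log units; within the scatter). On this aromatic carbon, next to the ring nitrogen, the same atoms can therefore be rearranged from 4-ethylpiperazin-1-yl into 3,4-dimethylpiperazin-1-yl, with one defined stereocentre added, and the half-life of compound 3 cannot be told apart from that of compound 2. Nothing available explains why these two groups read alike, and no supporting measurement bears on this result.

All the groups shown at this position are substituted piperazines, so it remains open whether a morpholine ring or an open-chain dimethylamino group on the same carbon would give a step beyond the scatter. Among the compounds shown here, also open are the mirror-image form of the 3,4-dimethylpiperazin-1-yl group and a larger group on the piperazine nitrogen, such as isopropyl or cyclopropyl, since the single step here covers only one rearrangement of the same atoms.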